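Aniline replacement in a quinazoline-type cytotoxicity series

The compounds below may be only part of what the source reports. "The series", "measured", "known", "first", "only" and "open" are said of these compounds alone.

Measured compounds:
compound 1 `CCS(=O)(=O)Nc1cc(-c2ccc3ncnc(Nc4cccc(C(=O)OC)c4)c3c2)cnc1OC` 1100 nM
compound 2 `CCS(=O)(=O)Nc1cc(-c2ccc3ncnc(Nc4ccc(Cl)c(C(=O)OC)c4)c3c2)cnc1OC` 2130 nM
compound 3 `CCS(=O)(=O)Nc1cc(-c2ccc3ncnc(Nc4ccc(C(=O)OC)c(OC)c4)c3c2)cnc1OC` 3350 nM

In a functional assay on A549 cells (Homo sapiens) for cytotoxicity, read by sulforhodamine B assay, with a stated time of 72 h (on this read-out lower numbers stand for stronger inhibition and higher numbers for weaker inhibition), compound 3 gives the highest of the three numbers; the step of a 3.0-fold higher number from compound 1 to compound 3 (0.48 log units; beyond the scatter) lies beyond the scatter, while the step of a 1.6-fold higher number from compound 2 to compound 3 (0.20 log units; within the scatter) does not. Compound 4 `CCS(=O)(=O)Nc1cc(-c2ccc3ncnc(Nc4ccc(OC)nc4)c3c2)cnc1OC` differs from compound 3 by 6-methoxypyridin-3-yl in place of 3-methoxy-4-(methoxycarbonyl)phenyl on a nitrogen on an aromatic ring. For the measured compounds named here, no measured step removes the methoxycarbonyl group or introduces a ring nitrogen; the steps of a 1.9-fold higher number from compound 1 to compound 2 (0.29 log units; within the scatter) and a 3.0-fold higher number from compound 1 to compound 3 (0.48 log units; beyond the scatter) only vary substituents on the same phenyl ring, and both are small. A step of similar, uncertain size in either direction is therefore expected for a 1.3-fold lower number from compound 3 to compound 4 (0.13 log units; within the scatter). Compound 4 is estimated at 2500 nM, with a range from 700 nM to 9000 nM in this assay.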

Compound 4, half-maximal inhibitory concentration: 5560 nM
Estimate against measurement, compound 4: 2.2-fold (0.35 log units) below; measured number inside the range.
By their numbers in this assay, from the lowest: compounds 1, 2, 3 and 4 (each within the scatter of the next, the first and the last beyond it).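

In this assay a ring without the methoxycarbonyl group and with a ring nitrogen still stays close to the substituted phenyl of the previous compound on this nitrogen: 6-methoxypyridin-3-yl gives a 1.7-fold higher number from compound 3 to compound 4 (0.22 log units; within the scatter) as its step. For the compounds shown here, the same replacement gives a 2.6-fold higher number from compound 2 to compound 4 (0.42 log units; beyond the scatter) and also a 5.1-fold higher number from compound 1 to compound 4 (0.70 log units; beyond the scatter) as the steps from the other two rings, the second being the largest step at this position so far. No measurement here explains these steps.

From the compounds shown here alone, the ring nitrogen and the loss of the methoxycarbonyl group change together, so their separate contributions remain open. Also open, going by these compounds, is how a carboxylic acid or an amine on this ring would read.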